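A few compounds are considered here, and "the series" means these few. Any claim that something is new, unique, unknown or untested is made for them only; others in the source may bear on it.

Measured in a functional assay for inhibition, with Homo sapiens as the target; on this read-out lower numbers stand for tighter binding and higher numbers for weaker binding:
compound 1 `O=C(O)CC/C=C\CC1COC(c2ccccc2Cl)OC1c1cccnc1`: 759 nM
compound 2 `N#Cc1ccccc1C1OCC(C/C=C\CCC(=O)O)C(c2cccnc2)O1`: 245 nM
compound 3 `O=C(O)CC/C=C\CC1COC(c2cccs2)OC1c1cccnc1`: 1000 nM

In this short series, compound 3 cannot be told apart from compound 1, as a 1.3-fold higher number from compound 1 to compound 3 (0.12 log units; within the scatter) shows. Compound 2 stands clearly apart from it, with a 4.1-fold higher number from compound 2 to compound 3 (0.61 log units; beyond the scatter). The next compound, compound 4 `O=C(O)CC/C=C\CC1COC(c2ccco2)OC1c1cccnc1`, keeps the shared core and carries furan-2-yl in place of thiophen-2-yl on a saturated ring carbon, between two ring oxygen atoms (furan-2-yl in place of thiophen-2-yl on a saturated ring carbon).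

Going by the values given here, no measured step makes this exact exchange, so the evidence is indirect. Two steps change the group at the same place. One is a 1.3-fold higher number from compound 1 to compound 3 (0.12 log units; within the scatter), in which thiophen-2-yl replaces 2-chlorophenyl, and the other is a 4.1-fold higher number from compound 2 to compound 3 (0.61 log units; beyond the scatter), in which thiophen-2-yl replaces 2-cyanophenyl. Both are exchanges of a six-membered aromatic group for a five-membered one, whereas compound 4 swaps one five-membered aromatic ring for another with the same heavy-atom count. The remaining step, a 3.1-fold lower number from compound 1 to compound 2 (0.49 log units; beyond the scatter), shows that a modest shift is possible within this series, so the range is kept wide. No step beyond the scatter is expected in this assay, and the expected change is no change at the digits printed from compound 3 to compound 4 (within the scatter). For compound 4 the estimated value is 1000 nM, with an expected range from 450 nM to 2200 nM.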

Compound 4, dissociation constant: 1260 nM
The estimate for compound 4 lay 1.3-fold (0.10 log units) below the measured number, within the range that was stated.
By their numbers in this assay, from the lowest: compound 2; then compounds 1, 3 and 4 (each within the scatter of the next).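

In this assay, going by these compounds alone, the step of furan-2-yl in place of thiophen-2-yl on this saturated ring carbon, between two ring oxygen atoms, is the first to exchange one five-membered aromatic ring for another, and a 1.3-fold higher number from compound 3 to compound 4 (0.10 log units; within the scatter) shows that oxygen and sulfur as the ring hetero atom cannot be told apart here. Compound 4 also cannot be told apart from the 2-chlorophenyl compound, with a 1.7-fold higher number from compound 1 to compound 4 (0.22 log units; within the scatter) as the step, whereas a 5.1-fold higher number from compound 2 to compound 4 (0.71 log units; beyond the scatter) keeps the 2-cyanophenyl compound clearly separate, so that of the four groups at this position only 2-cyanophenyl stands apart. No measurement is available to explain these steps or the separate standing of compound 2.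

The compounds shown leave open whether a nitrile on a thiophene or furan ring would bring the number close to that of compound 2, and whether a saturated group such as cyclohexyl would behave like the aromatic groups at this carbon. They also leave open what would happen if a tetrazole or an amide replaced the carboxylic acid, which is common to all four compounds.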